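Swapping the halogen pattern on the benzyl group

The source may report more compounds than this note shows. Statements on the series, on what has been measured and on what is new or still open speak of the compounds shown alone.

Compound 1 `OC[C@H]1O[C@@H](n2cnc3c(NCc4ccc(Cl)cc4)ncnc32)[C@H](O)[C@@H]1O` stands as the weaker of the two compounds that give a number in a functional assay on K562 cells (Homo sapiens) for antiproliferative activity, with a stated time of 72 h; on this read-out lower numbers stand for stronger inhibition and higher numbers for weaker inhibition: in this assay compound 1 gives 218000 nM. Compound 3 `OC[C@H]1O[C@@H](n2cnc3c(NCc4ccc(Cl)c(Cl)c4)ncnc32)[C@H](O)[C@@H]1O` gives 10800 nM, so the step of a 20-fold lower number from compound 1 to compound 3 (1.31 log units; beyond the scatter) is a large one. Compound 2 `Cc1cccc(CNc2ncnc3c2ncn3[C@@H]2O[C@H](CO)[C@@H](O)[C@H]2O)c1` reaches only a limit of the assay, > 166000 nM (the limit of > 166000 nM in this assay, at which 1 of the 3 values shown sits). The step that the limit leaves unreadable from compound 1 to compound 2 therefore cannot be read. Compound 4 `OC[C@H]1O[C@@H](n2cnc3c(NCc4ccc(F)cc4F)ncnc32)[C@H](O)[C@@H]1O` has not been measured; it differs from compound 1 in one place: 2,4-difluorophenyl in place of 4-chlorophenyl on a saturated chain carbon bound to a nitrogen on an aromatic ring. Among the compounds with values here, the one readable step, a 20-fold lower number from compound 1 to compound 3 (1.31 log units; beyond the scatter), concerns chloro in place of hydrogen on an aromatic carbon, whereas the change to compound 4 removes the chloro altogether and brings in 2,4-difluorophenyl, a change no measured step describes. The expected step of a 1.1-fold higher number from compound 1 to compound 4 (0.06 log units; within the scatter) is therefore small, with wide uncertainty. Compound 4 is estimated at 250000 nM, within a range from 60000 nM to 1000000 nM.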

Compound 4, half-maximal inhibitory concentration: 9600 nM
Estimate against measurement, compound 4: 26-fold (1.42 log units) above; measured number outside the range, below it.
By their numbers in this assay, from the lowest: compounds 4 and 3 (each within the scatter of the next); then compound 1.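

Chloro need not be on the ring for a low number in this assay: 2,4-difluorophenyl gives a 23-fold lower number from compound 1 to compound 4 (1.36 log units; beyond the scatter), and the two halogen patterns cannot be told apart, with a 1.1-fold lower number from compound 3 to compound 4 (0.05 log units; within the scatter). Among the halogenated compounds shown, then, only compound 1 stays high, and replacing 3-methylphenyl gives an at least 17-fold lower number from compound 2 to compound 4 (1.23 log units; beyond the scatter). Compound 2 stands at a limit and not at a number, so that last step has an open end: the limit of > 166000 nM in this assay, at which 1 of the 4 values shown sits.

Whether one of the two fluoro atoms alone would be enough remains open, since the compounds shown carry them only as a pair. Also open, on these data alone, is what a methoxy group on the ring, or a longer chain in place of the single saturated carbon, would do to the number.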